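The compounds below may be only part of what the source reports. "The series", "measured", "known", "first", "only" and "open" are said of these compounds alone.

Compound 1, `O=[N+]([O-])c1cn2c(n1)OC[C@@H](OCc1ccn(-c3ccc(F)cc3)n1)C2`, gives in an ADME assay on Vero cells (Chlorocebus sabaeus) for cytotoxicity, with a stated time of 72 h (a higher number here means a weaker inhibitor, a lower number a stronger inhibitor), only the limit > 128000 nM, which is a boundary of the measurement and not a number.
Compound 2, `O=[N+]([O-])c1cn2c(n1)OC[C@@H](OCc1ccn(-c3ccc(OC(F)(F)F)cc3)n1)C2`, gives in this assay only the limit > 128000 nM.
Compound 3, `O=[N+]([O-])c1cn2c(n1)OC[C@@H](OCc1cc(-c3ccc(F)cc3)no1)C2`, gives in this assay only the limit > 128000 nM.

From compound 1 to compound 2 one change is made: trifluoromethoxy in place of fluoro on an aromatic carbon. Since both sit at a limit, the step that the two limits leave unreadable from compound 1 to compound 2 cannot be read. Compound 3 carries a different core from compound 1; the difference between the two cores is not broken down here. The compound not yet measured, compound 4, `O=[N+]([O-])c1cn2c(n1)OC[C@@H](OCc1cc(-c3ccc(OC(F)(F)F)cc3)no1)C2`, arises from compound 3 by the same change: trifluoromethoxy in place of fluoro on an aromatic carbon. All that is known about this change in this assay is the limit of > 128000 nM in this assay, at which 3 of the 3 values shown sit, three values resting at the same boundary. Among the measured compounds shown here, the step from compound 3 to compound 4 is therefore expected to be small, roughly a step that the limit leaves unreadable from compound 3 to compound 4, because the limit of > 128000 nM in this assay, at which 3 of the 3 values shown sit, shows no compound departing from that limit. Compound 4 is accordingly expected to give about 160000 nM, most likely again only a limit, within 60000 nM to 450000 nM.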

Compound 4, half-maximal inhibitory concentration: > 128000 nM
Compound 4 ended at the assay's limit; the forecaster's own chance of this, stated with the estimate: 85%; the middle value lies beyond the limit too.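

Compound 3 and compound 4 both stop at a limit in this assay rather than giving a number, so the step from one to the other cannot be read. The compounds shown leave open how far each lies past that boundary, and whether trifluoromethoxy in place of fluoro changes the read-out at all, because all of them rest at the same point: the limit of > 128000 nM in this assay, at which 4 of the 4 values shown sit.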